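Dropping the Bromine from a Thiadiazole Cinnamamide

The source may hold more compounds than are shown below. What is called first, only, known or untested is meant among the compounds shown, and "the series" means these compounds.

Measured so far, in a functional assay on A549 cells (Homo sapiens) for antiproliferative activity, read by MTT assay, with a stated time of 48 h; a lower number here means a stronger inhibitor, a higher number a weaker inhibitor:
compound 1 `O=C(/C=C/c1ccccc1)Nc1nnc(-c2ccccc2)s1` gives 1.75 ug/mL
compound 2 `Cc1ccc(/C=C/C(=O)Nc2nnc(-c3ccc(Br)cc3)s2)cc1` gives 1.51 ug/mL
compound 3 `O=C(/C=C/c1ccc(C(F)(F)F)cc1)Nc1nnc(-c2ccc(Br)cc2)s1` gives 4.68 ug/mL

Compound 3 stands highest of the three numbers in this assay: its nearest neighbour is compound 1, and its furthest is compound 2, both gaps beyond the scatter. Going by the values given here, the only single-place step seen so far is a 3.1-fold higher number from compound 2 to compound 3 (0.49 log units; beyond the scatter), which is where the trifluoromethyl enters the series.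

Compound 4 `O=C(/C=C/c1ccc(C(F)(F)F)cc1)Nc1nnc(-c2ccccc2)s1` keeps that trifluoromethyl and differs from compound 3 only in this: hydrogen in place of bromo on an aromatic carbon. Among the compounds with values here, no measured step touches this particular change. Compound 1 and compound 2 differ at two places at once, and their two values lie within the scatter of each other, which gives no sign that the bromo matters much either way. The expectation for the step is therefore a 1.1-fold lower number from compound 3 to compound 4 (0.05 log units; within the scatter), no change beyond the scatter in this assay, with wide uncertainty. Compound 4 is estimated at 4.2 ug/mL, in a range from 2 ug/mL to 9 ug/mL.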

Compound 4, half-maximal inhibitory concentration: 1.78 ug/mL
Compound 4: the middle estimate sits 2.4-fold (0.37 log units) above what was measured; measured number below the stated range.
By their numbers in this assay, from the lowest: compounds 2, 1 and 4 (each within the scatter of the next); then compound 3.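

In this assay, the bromo turns out to matter at this position when trifluoromethyl is on the other ring: hydrogen in its place gives a 2.6-fold lower number from compound 3 to compound 4 (0.42 log units; beyond the scatter). With hydrogen at this position, the trifluoromethyl makes no difference beyond the scatter, a 1.0-fold higher number from compound 1 to compound 4 (0.01 log units; within the scatter), so among the compounds shown, the higher number of compound 3 appears only where bromo and trifluoromethyl occur together. Nothing available bears on why these two groups act in this way.

Going by these compounds, whether the bromo carries any weight in the methyl-bearing compound 2 remains open. Also open, on these data alone, is whether another group at this position, such as chloro or an amine, would track with hydrogen or with bromo in the trifluoromethyl compounds.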